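The source may report more compounds than this note shows. Statements on the series, on what has been measured and on what is new or still open speak of the compounds shown alone.

Of the compounds shown here, two that share a core have been measured so far in an in vitro ADME assay on microsomes from liver (Mus musculus) for pharmacokinetics, read by LC-MS, with a stated time of 60 min, tested at 5 uM; a higher number here means faster removal of the compound, a lower number slower removal. Compound 1 (`COc1ccc(C(N)=O)cc1COc1ccc(Cl)cc1`) gives 97 mL.min-1.g-1, and compound 2 (`COc1ccc(C(N)=O)cc1/C=C/c1ccc(Cl)cc1`) gives 110 mL.min-1.g-1. These two numbers lie within the usual scatter of each other, so compound 2 stands level with compound 1 and neither can be ranked above the other. Compound 3 (`COc1ccc(C(N)=O)cc1/C=C\c1ccc(Cl)cc1`) has not yet been measured in this assay. Between compound 2 and compound 3, (the two compounds have the same atoms and bonds and differ only in configuration as drawn: 1 of 1 stereo elements differ; a double bond is drawn E in compound 2 and Z in compound 3). For the measured compounds named here, no measured pair shows what such a switch does, so the data point in no direction, and no shift beyond the scatter is expected. The expected step is a 1.1-fold lower number from compound 2 to compound 3 (0.04 log units; within the scatter). For compound 3 the estimated value is 100 mL.min-1.g-1, with an expected range from 50 mL.min-1.g-1 to 200 mL.min-1.g-1.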

Compound 3, intrinsic clearance in microsomes: 544 mL.min-1.g-1
Compound 3: the middle estimate sits 5.4-fold (0.74 log units) below what was measured; the measured number lies above the stated range.
By their numbers in this assay, from the lowest: compounds 1 and 2 (each within the scatter of the next); then compound 3.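

For the compounds shown here, the configuration of this double bond turns out to matter in this assay, which the earlier compounds could not show, as no measured pair had isolated such a switch. Going from E to Z gives a 4.9-fold higher number from compound 2 to compound 3 (0.69 log units; beyond the scatter), so the Z form is removed faster. The step can be tied to the double bond's geometry alone, because no atom or bond changes between the two compounds: the fact that compounds 2 and 3 differ only in the configuration as drawn.

On these data alone, what remains open is why the Z form is cleared faster, since these numbers say nothing about where or how the compounds are broken down. It is also unclear whether the E and Z forms would differ as much with a nitrile in place of the chlorine, or whether a saturated chain in place of the double bond would sit nearer compound 2 or compound 3.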